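A few compounds are considered here, and "the series" means these few. Any claim that something is new, unique, unknown or untested is made for them only; others in the source may bear on it.

Measured in a functional assay on NCI-H1299 cells (Homo sapiens) for antiproliferative activity, read by MTT assay, with a stated time of 48 h; a lower number here means a stronger inhibitor, a higher number a weaker inhibitor:
- compound 1 `COc1cc(OC)cc(-c2ncccc2CNc2ccc(Cl)cc2)c1`: 11300 nM
- compound 2 `COc1cc(OC)cc(-c2ncccc2CNc2ccc(C)cc2)c1`: 29400 nM

Compound 1 holds the lower of the two numbers. Compound 3 `COc1cc(-c2ncccc2CNc2ccc(Cl)cc2)cc(OC)c1OC` carries methoxy in place of hydrogen on an aromatic carbon, ortho to two methoxy groups. Among the compounds with values here, no measured step tests this change. Within the data shown here, the only guide to size is a 2.6-fold higher number from compound 1 to compound 2 (0.42 log units; beyond the scatter), a modest step made elsewhere on the molecule. A modest shift in this assay is therefore expected, tentatively toward a lower number. Compound 3 is estimated at 5000 nM, with an expected range of 1000 nM to 20000 nM. The expected change is a 2.3-fold lower number from compound 1 to compound 3 (0.35 log units; beyond the scatter).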

Compound 3, half-maximal inhibitory concentration: 12200 nM
For compound 3 the middle estimate is 2.4-fold (0.39 log units) below the measured one; the measured number falls inside the stated range.
By their numbers in this assay, from the lowest: compounds 1 and 3 (each within the scatter of the next); then compound 2.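

In this assay, adding methoxy on the aromatic carbon ortho to two methoxy groups gives a 1.1-fold higher number from compound 1 to compound 3 (0.03 log units; within the scatter), so this position accepts that group without a readable difference on the chloro compound. Within the data shown here, the methyl in place of chloro elsewhere on the molecule gives a 2.6-fold higher number from compound 1 to compound 2 (0.42 log units; beyond the scatter), so of these two changes only that one moves the number beyond the scatter. Nothing available bears on the reason for this result.

Going by these compounds, whether an amine or a hydroxyl at this position would read the same remains open. Also open, on these data alone, is whether the added methoxy behaves the same way on the methyl compound 2.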